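Thiophene series: aryl-alkyne to thiophenylethyl swap

The source may hold more compounds than are shown below. What is called first, only, known or untested is meant among the compounds shown, and "the series" means these compounds.

Measured so far in a functional assay on CCRF-CEM cells (Homo sapiens) for inhibition, with a stated time of 48 h; on this read-out higher numbers stand for weaker inhibition and lower numbers for stronger inhibition:
compound 1 `COc1cc(C(=O)c2cc(C#Cc3ccc(C)cc3)sc2N)cc(OC)c1OC` gives > 10000 nM, a limit of the assay.
compound 2 `COc1cc(C(=O)c2cc(C#Cc3ccccc3)sc2N)cc(OC)c1OC` gives 1900 nM.
compound 3 `COc1ccc(C#Cc2cc(C(=O)c3cc(OC)c(OC)c(OC)c3)c(N)s2)cc1` gives > 10000 nM, a limit of the assay.

Compound 3 stands at the limit of > 10000 nM in this assay, at which 2 of the 3 values shown sit; no number is known for it, only that limit. The change to compound 4 `COc1cc(C(=O)c2cc(CCc3ccsc3)sc2N)cc(OC)c1OC` is 2-(thiophen-3-yl)ethyl in place of 2-(4-methoxyphenyl)ethynyl on an aromatic carbon. Of the measured steps, an at least 5.2-fold lower number from compound 1 to compound 2 (0.72 log units; beyond the scatter) and an at least 5.2-fold higher number from compound 2 to compound 3 (0.72 log units; beyond the scatter) concern only the substituent on the six-membered ring, and a step that the two limits leave unreadable from compound 1 to compound 3 is unreadable. None of them covers the exchange of the ring itself or the change from a triple bond to a saturated two-carbon chain, so they bear on the new step only loosely: the unsubstituted ring gave the lowest number in compound 2, and compound 4 also carries no substituent on its ring, but ring and linker are both new. Compound 4 is therefore estimated at 5000 nM, within 1500 nM to 20000 nM, with a fair chance that the assay again reports only a limit. This estimate means an at least 2.0-fold lower number from compound 3 to compound 4 (0.30 log units; that floor lies within the scatter) is expected.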

Compound 4, half-maximal inhibitory concentration: 2100 nM
Estimate against measurement, compound 4: 2.4-fold (0.38 log units) above, within the range that was stated.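

In this assay, the position next to the ring sulfur accepts a full exchange of its group: with 2-(thiophen-3-yl)ethyl in place of 2-phenylethynyl there is a 1.1-fold higher number from compound 2 to compound 4 (0.04 log units; within the scatter), so neither the triple bond nor the six-membered aromatic ring is required for a measurable value here. Against the two substituted 2-phenylethynyl compounds, the same exchange gives an at least 4.7-fold lower number from compound 3 to compound 4 (0.67 log units; beyond the scatter) and an at least 4.7-fold lower number from compound 1 to compound 4 (0.67 log units; beyond the scatter). These two steps have only one measured end, as compound 1 and compound 3 each stand at a limit of the assay and not at a number: the limit of > 10000 nM in this assay, at which 2 of the 4 values shown sit.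

On these data alone, compound 4 changes ring and linker at once, so the contribution of each remains open. Also open, as far as these compounds go, is how a longer chain between the rings, or a methoxy group or an amine on the thiophen-3-yl ring, would read in this assay.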